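This account rests on a few compounds, and the source may have more. Where it says the series, first, only, none or still open, it means among the compounds named here.

Working notes on the series. Compound 1 `CC(C)(C)COC(=O)N1CCC2(CC1)CC(CCCOc1ccc(S(C)(=O)=O)c(F)c1)C2` and compound 2 `CC(C)OC(=O)N1CCC2(CC1)CC(CCCOc1ccc(C(=O)N(C)C3CC3)c(F)c1)C2` share the same core and differ only at the far end of the chain. In a functional assay on cells for agonist activity at Glucose-dependent insulinotropic receptor (Homo sapiens), read by HTRF and cAMP accumulation, with a stated time of 30 min (a lower number here means that less compound is needed, a higher number that more compound is needed for the effect), compound 1 gives 31 nM, while compound 2 gives 67 nM, the higher of the two numbers. Compound 3 `CC(C)OC(=O)N1CCC2(CC1)CC(CCCOc1ccc(C(=O)NCC(N)=O)c(F)c1)C2` is not yet measured; it differs from compound 2 by (carbamoylmethyl)amino in place of cyclopropyl(methyl)amino on a carbonyl carbon. Within the data shown here, no measured pair shows this kind of exchange, so the step is expected to be modest, pointing toward a higher number, at about a 2.2-fold higher number from compound 2 to compound 3 (0.35 log units; beyond the scatter). For compound 3 the expected value in this assay is 150 nM, within 50 nM to 500 nM.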

Compound 3, half-maximal effective concentration: 48 nM
Beside the measured number, compound 3's estimate is 3.1-fold (0.49 log units) above it, and the stated range ends above it.
By their numbers in this assay, from the lowest: compounds 1, 3 and 2 (each within the scatter of the next, the first and the last beyond it).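

In this assay, the exchange on a carbonyl carbon gives a 1.4-fold lower number from compound 2 to compound 3 (0.14 log units; within the scatter). This position therefore accepts (carbamoylmethyl)amino, with no ring and with hydrogen-bond donors, in place of cyclopropyl(methyl)amino without a shift beyond the scatter, so the three-membered ring is not needed for activity in this pair. Nothing shown accounts for this result. Still open, as far as these compounds go, is whether an amine or a carboxylic acid at the end of a longer chain on this carbonyl carbon would also stay within the scatter of compound 2.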